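The source may hold more compounds than are shown below. What is called first, only, known or untested is meant among the compounds shown, and "the series" means these compounds.

The measured compounds in an assay on CHO cells for antagonist activity at transient receptor potential cation channel subfamily V member 1 (Homo sapiens), read by FLIPR; on this read-out lower numbers stand for stronger inhibition and higher numbers for weaker inhibition:
Compound 1 `CC(C(=O)NCc1ccc(C(F)(F)F)cc1N1CCCCCCC1)c1ccc(NS(C)(=O)=O)c(F)c1`: 2.8 nM
Compound 2 `CC(C(=O)NCc1ccc(C(F)(F)F)cc1OCc1ccc(F)cc1)c1ccc(NS(C)(=O)=O)c(F)c1`: 0.5 nM
Compound 3 `CCCCCCSc1cc(C(F)(F)F)ccc1CNC(=O)C(C)c1ccc(NS(C)(=O)=O)c(F)c1`: 1.8 nM

Compound 1 has the highest number of the three. Compound 3 is nearest, a 1.6-fold lower number from compound 1 to compound 3 (0.19 log units; within the scatter), and compound 2 is furthest, a 5.6-fold lower number from compound 1 to compound 2 (0.75 log units; beyond the scatter). Between those two, a 3.6-fold higher number from compound 2 to compound 3 (0.56 log units; beyond the scatter). Compound 4 `CC(C)CCSc1cc(C(F)(F)F)ccc1CNC(=O)C(C)c1ccc(NS(C)(=O)=O)c(F)c1` has not yet been measured; it differs from compound 1 in one place: a group of 6 heavy atoms (5 carbon, 1 sulfur; no ring) in place of a group of 8 heavy atoms (7 carbon, 1 nitrogen; one eight-membered non-aromatic ring with 1 hetero atom), on an aromatic carbon. The step from compound 1 to compound 3 bears most on this, a sulfur-linked chain in place of the ring, and it stayed within the scatter. With a chain of the same kind entering in compound 4, a similar outcome is expected, no step beyond the scatter, a 1.4-fold lower number from compound 1 to compound 4 (0.15 log units; within the scatter). Compound 4 is therefore estimated at 2 nM, within a range from 0.7 nM to 6 nM.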

Compound 4, inhibition constant: 1.4 nM
The estimate for compound 4 lay 1.4-fold (0.15 log units) above the measured number; measured number inside the range.
By their numbers in this assay, from the lowest: compound 2; then compounds 4, 3 and 1 (each within the scatter of the next).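

In this assay, a second sulfur-linked chain, the branched isopentylsulfanyl, also stands in for the eight-membered ring without a step beyond the scatter (a 2.0-fold lower number from compound 1 to compound 4 (0.30 log units; within the scatter)). Going from hexylsulfanyl to isopentylsulfanyl at this position also stays within the scatter (a 1.3-fold lower number from compound 3 to compound 4 (0.11 log units; within the scatter)), while (4-fluorobenzyl)oxy remains apart from this chain (a 2.8-fold higher number from compound 2 to compound 4 (0.45 log units; beyond the scatter)). No evidence here accounts for these numbers. Still open, as far as these compounds go, is how a much shorter chain such as methylsulfanyl would read. A hexyloxy chain or a (4-fluorobenzyl)sulfanyl group would separate the linking atom from the group it carries.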